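A Methyl for a Methoxy on Two Related Cores

The source may hold more compounds than are shown below. What is called first, only, known or untested is meant among the compounds shown, and "the series" means these compounds.

Compound 1 `COc1ccc2[nH]c3c4cn[nH]c4c4c(c3c2c1)C(=O)NC4=O` carries a methoxy group. In a functional assay on PC-3 cells (Homo sapiens) for cytotoxicity, read by MTT assay, with a stated time of 72 h (a lower number here means a stronger inhibitor, a higher number a weaker inhibitor), compound 1 gives > 100000 nM, which is a limit of the assay rather than a number. Compound 2 `Cc1ccc2[nH]c3c4cn[nH]c4c4c(c3c2c1)C(=O)NC4=O` differs from it by methyl in place of methoxy on an aromatic carbon. In this assay compound 2 gives > 100000 nM, again only a limit. The step from compound 1 to compound 2 is therefore a step that the two limits leave unreadable from compound 1 to compound 2 because both values sit at the limit of > 100000 nM in this assay, at which 3 of the 3 values shown sit. Compound 3 `COc1ccc2[nH]c3c(c4c(c5ccnn53)C(=O)NC4=O)c2c1` keeps the methoxy group but is built on a different core; the difference between the two cores is not broken down here. In this assay compound 3 gives > 100000 nM, once more a limit. Compound 4 `Cc1ccc2[nH]c3c(c4c(c5ccnn53)C(=O)NC4=O)c2c1` has not yet been measured and differs from compound 3 by methyl in place of methoxy on an aromatic carbon, the same change as that from compound 1 to compound 2. That earlier change could not be read, and every value shown sits at the limit of > 100000 nM in this assay, at which 3 of the 3 values shown sit, so for compound 4 the expected step is a step that the limit leaves unreadable from compound 3 to compound 4. Compound 4 is estimated at 150000 nM in this assay, most probably reported again only as a limit.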

Compound 4, half-maximal inhibitory concentration: 75000 nM
Estimate against measurement, compound 4: 2.0-fold (0.30 log units) above, within the range that was stated.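

On the core of compound 3, methyl in place of methoxy gives an at least 1.3-fold lower number from compound 3 to compound 4 (0.12 log units; that floor lies within the scatter) in this assay. Compound 3 gives > 100000 nM, which is a limit and not a number, so the true step could be larger than this floor, but a floor within the scatter does not by itself show that the change made a real difference. The same change on the core of compound 1 cannot be read, so the two cores cannot be compared and nothing shows that the change carries from one to the other, because the values there sit at a shared limit: the limit of > 100000 nM in this assay, at which 3 of the 4 values shown sit.

An amine, a carboxylic acid or a longer chain such as propyl on the same aromatic carbon might read differently in this assay, and the compounds shown do not tell. They also leave open whether any such group would bring the core of compound 1 to a readable number.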